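The compounds below may be only part of what the source reports. "The series", "measured", "known", "first", "only" and "open" are said of these compounds alone.

Compound 1 `COc1cc(-c2nnc3n2NC(c2cccs2)C(C(=O)c2ccccc2)S3)cc(OC)c1OC` gives 69400 nM in a functional assay on A549 cells (Homo sapiens) for cytotoxicity, read by MTT assay, with a stated time of 48 h; on this read-out higher numbers stand for weaker inhibition and lower numbers for stronger inhibition. Compound 2 `COc1cc(-c2nnc3n2NC(c2cccs2)C(C(=O)c2ccc(F)cc2)S3)cc(OC)c1OC` gives 45000 nM in this assay, and the step of a 1.5-fold lower number from compound 1 to compound 2 (0.19 log units; within the scatter) stays within the scatter. Compound 3 `COc1cc(-c2nnc3n2NC(c2ccco2)C(C(=O)c2ccc(C)cc2)S3)cc(OC)c1OC` reaches only the limit > 100000 nM in this assay, so its value is a limit and not a number. Compound 4 `COc1cc(-c2nnc3n2NC(c2ccco2)C(C(=O)c2ccc(O)cc2)S3)cc(OC)c1OC` differs from compound 3 by hydroxy in place of methyl on an aromatic carbon. For the measured compounds named here, no measured step exchanges a methyl for a hydroxy; the single measured step concerns a different change and lies within the scatter, while one value sits at the limit of > 100000 nM in this assay, at which 1 of the 3 values shown sits. The expected change is a number no higher from compound 3 to compound 4 (the limit leaves the size open), no larger than the scatter. Compound 4 is estimated at 100000 nM, in a range from 40000 nM to 250000 nM, with a real chance that this assay again reports only a limit.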

Compound 4, half-maximal inhibitory concentration: 93400 nM
Beside the measured number, compound 4's estimate is 1.1-fold (0.03 log units) above it; low and high end bracket the measured number.
By their numbers in this assay, from the lowest: compounds 2, 1 and 4 (each within the scatter of the next, the first and the last beyond it). At a limit, above all of these: compound 3.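

In this assay, the exchange of 4-methylphenyl for 4-hydroxyphenyl yields an at least 1.0-fold lower number from compound 3 to compound 4 (0.02 log units; that floor lies within the scatter), the first step measured with a hydrogen-bond donor entering this position. With hydroxy there, compound 4 gives 93400 nM, a measured number rather than a limit. The true size of the step stays unknown, since the value of compound 3 is a limit and not a number: the limit of > 100000 nM in this assay, at which 1 of the 4 values shown sits.

The compounds shown leave open whether an amine or a carboxylic acid in this position would move the number beyond the scatter. They also leave open whether hydroxy would act alike on the core of compound 1.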